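Swapping the Benzylic Hydantoin for a Pyrazolyl Ketone

The compounds below may be only part of what the source reports. "The series", "measured", "known", "first", "only" and "open" are said of these compounds alone.

Compound 3 `CCCCOC(=O)NS(=O)(=O)c1sc(CC(C)C)cc1-c1ccc(CN2C(=O)N(C)C(C)(C)C2=O)cc1` gives 3.6 nM in an assay on membranes from uterus for displacement of a labelled ligand from Angiotensin type II receptor (Sus scrofa), with a stated time of 1.5 h (a higher number here means a weaker inhibitor, a lower number a stronger inhibitor), the lowest of the three numbers shown, though compound 1 `CCCCOC(=O)NS(=O)(=O)c1sc(CC(C)C)cc1-c1ccc(Cc2ncco2)cc1` gives 3.9 nM and the two lie within the scatter (a 1.1-fold lower number from compound 1 to compound 3 (0.03 log units; within the scatter)). Compound 2 `CCCCOC(=O)NS(=O)(=O)c1sc(CC(C)C)cc1-c1ccc(Cc2nnc(C(F)(F)F)o2)cc1` gives 328 nM, and the steps of an 84-fold higher number from compound 1 to compound 2 (1.92 log units; beyond the scatter) and a 91-fold lower number from compound 2 to compound 3 (1.96 log units; beyond the scatter) show that the group on this aromatic carbon can move the number a great deal. Compound 4 `CCCCOC(=O)NS(=O)(=O)c1sc(CC(C)C)cc1-c1ccc(C(=O)c2ccnn2C)cc1` carries a group of 8 heavy atoms (5 carbon, 2 nitrogen, 1 oxygen; one five-membered aromatic ring with 2 hetero atoms) in place of a group of 11 heavy atoms (7 carbon, 2 nitrogen, 2 oxygen; one five-membered non-aromatic ring with 2 hetero atoms), on an aromatic carbon. Within the data shown here, no measured step covers a carbonyl link or a pyrazole, so the direction is uncertain. The step of an 84-fold higher number from compound 1 to compound 2 (1.92 log units; beyond the scatter) was large while the step of a 1.1-fold lower number from compound 1 to compound 3 (0.03 log units; within the scatter) stayed within the scatter. For compound 4 a modest weakening is expected, a 4.2-fold higher number from compound 3 to compound 4 (0.62 log units; beyond the scatter). Compound 4 is estimated at 15 nM, with a range from 3 nM to 100 nM.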

Compound 4, inhibition constant: 3.4 nM
Beside the measured number, compound 4's estimate is 4.4-fold (0.64 log units) above it, within the range that was stated.
By their numbers in this assay, from the lowest: compounds 4, 3 and 1 (each within the scatter of the next); then compound 2.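

The (1-methyl-1H-pyrazol-5-yl)carbonyl group sits directly on the aromatic carbon, with no saturated chain carbon, yet the number in this assay stays level with both the hydantoin (a 1.1-fold lower number from compound 3 to compound 4 (0.02 log units; within the scatter)) and the oxazole (a 1.1-fold lower number from compound 1 to compound 4 (0.06 log units; within the scatter)). This position therefore accepts a carbonyl-linked pyrazole as well as those two groups. Set against the trifluoromethyl oxadiazole, the same group gives a 96-fold lower number from compound 2 to compound 4 (1.98 log units; beyond the scatter), leaving that oxadiazole alone apart among the four. No measurement here bears on why these groups differ. Going by these compounds, whether an amine, a carboxylic acid or a pyrazole without its methyl would fit this position equally well remains open.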